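The compounds below may be only part of what the source reports. "The series", "measured", "known", "first", "only" and "open" are said of these compounds alone.

Three compounds have been measured in a functional assay on Z-138 cells (Homo sapiens) for antiproliferative activity, with a stated time of 72 h; a lower number here means a stronger inhibitor, a higher number a weaker inhibitor:

- compound 1, `Nc1ncnn2c([C@@H]3O[C@H](CO)[C@@H](O)[C@H]3O)cc(C#Cc3cccs3)c12`, gives 50100 nM
- compound 2, `Nc1ncnn2c([C@@H]3O[C@H](CO)[C@@H](O)[C@H]3O)cc(C#Cc3ccccc3)c12`, gives 41400 nM
- compound 3, `Nc1ncnn2c([C@@H]3O[C@H](CO)[C@@H](O)[C@H]3O)cc(-c3ccc(Cl)cc3)c12`, gives 40200 nM

Compound 3 has the lowest of the three numbers, but only barely: one gap is a 1.0-fold lower number from compound 2 to compound 3 (0.01 log units; within the scatter) and the other is a 1.2-fold lower number from compound 1 to compound 3 (0.10 log units; within the scatter), so none of the three can be set apart from the others. The step from compound 1 to compound 2, a 1.2-fold lower number from compound 1 to compound 2 (0.08 log units; within the scatter), likewise stays inside the scatter.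

Compound 4, `Cc1ccccc1-c1cc([C@@H]2O[C@H](CO)[C@@H](O)[C@H]2O)n2ncnc(N)c12`, is the next compound to be tested. It differs from compound 3 in one place: 2-methylphenyl in place of 4-chlorophenyl on an aromatic carbon. Going by the values given here, no measured step swaps one six-membered carbon ring for another at this position, so the change has no direct precedent. What the three measured steps do show is that every change tried so far at this site, whether a different ring on the triple-bonded carbon or a ring in place of the whole alkyne arm, left the number essentially unchanged. On that basis compound 4 is expected to land near compound 3, with a step of a 1.0-fold lower number from compound 3 to compound 4 (0.00 log units; within the scatter), which is no step beyond the scatter. The estimate for compound 4 is 40000 nM, within a range from 15000 nM to 100000 nM.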

Compound 4, half-maximal inhibitory concentration: 66000 nM
Compound 4: middle estimate off by 1.7-fold (0.22 log units), on the low side, and the stated range covers the measured number.
By their numbers in this assay, from the lowest: compounds 3, 2, 1 and 4 (each within the scatter of the next).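

Replacing 4-chlorophenyl with 2-methylphenyl, which has the same heavy-atom count and the same kind of six-membered carbon ring, gives a 1.6-fold higher number from compound 3 to compound 4 (0.22 log units; within the scatter) in this assay. Going by these compounds alone, this swap of one substituted carbon ring for another had no earlier example, and it stays inside the scatter, as do the comparisons with the two alkyne arms, a 1.6-fold higher number from compound 2 to compound 4 (0.20 log units; within the scatter) and a 1.3-fold higher number from compound 1 to compound 4 (0.12 log units; within the scatter), so the four compounds still cannot be told apart at this position. No evidence is available that would give a cause for these numbers.

On these data alone, all four groups at this aromatic carbon are built on a carbon-rich ring, either attached directly or through a triple bond, so it remains open whether something of a different kind there, such as an amine, a carboxylic acid or a longer chain, would shift the number beyond the scatter. As far as these compounds go, all four compounds also keep the rest of the shared core unchanged, including its amino group and hydroxymethyl group, and what a change at those places would do remains open too.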